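Swapping Bromo for Chloro on a Weak MCF7 Inhibitor

A few compounds are considered here, and "the series" means these few. Any claim that something is new, unique, unknown or untested is made for them only; others in the source may bear on it.

Of the compounds shown here, two sharing one core have been measured. Compound 1 `CCOC(=O)C1=C(N/N=C(\c2ccc([N+](=O)[O-])cc2)N2CCN(c3ccc(F)cc3)CC2)Nc2[nH]nc(C)c2C1c1ccc(N(C)C)cc1` gives > 100000 nM in a functional assay on MCF7 cells (Homo sapiens) for inhibition, read by MTT assay, with a stated time of 48 h (on this read-out lower numbers stand for stronger inhibition and higher numbers for weaker inhibition), which is a limit of the assay rather than a number. Compound 2 `CCOC(=O)C1=C(N/N=C(/C(=O)Br)c2ccc(Br)cc2)Nc2[nH]nc(C)c2C1c1ccc(N(C)C)cc1` gives 61300 nM in this assay and so holds the only real number shown. The value of compound 1 is a limit (the limit of > 100000 nM in this assay, at which 1 of the 2 values shown sits). Compound 3 `CCOC(=O)C1=C(N/N=C(/C(=O)Br)c2ccc(Cl)cc2)Nc2[nH]nc(C)c2C1c1ccc(N(C)C)cc1` differs from compound 2 by chloro in place of bromo on an aromatic carbon. Within the data shown here, no measured step covers such a change, so in this assay no shift beyond the usual scatter is expected. Compound 3 is therefore estimated at 70000 nM, between 25000 nM and 200000 nM. The expected step of a 1.1-fold higher number from compound 2 to compound 3 (0.06 log units; within the scatter) should stay within the scatter.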

Compound 3, half-maximal inhibitory concentration: 46300 nM
Compound 3: the middle estimate sits 1.5-fold (0.18 log units) above what was measured, and the stated range covers the measured number.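

In this assay, among these compounds, replacing 4-bromophenyl with 4-chlorophenyl gives a 1.3-fold lower number from compound 2 to compound 3 (0.12 log units; within the scatter), the first measured step at this position. Exchanging these two halogens therefore does not shift the number beyond the usual scatter of repeated measurements. Nothing shown here bears on why that is so. From the compounds shown here alone, whether a different kind of group at this position, such as an amine, a carboxylic acid or a methoxy group, would move the number beyond the scatter remains open. So does whether the same exchange would behave alike elsewhere on the shared core.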